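Vinyl sulfone analogues: swapping the aryl arm

A few compounds are considered here, and "the series" means these few. Any claim that something is new, unique, unknown or untested is made for them only; others in the source may bear on it.

Measured compounds:
- compound 1, `Cc1ccc(S(=O)(=O)/C(=C/c2sccc2C)C(=O)c2ccc(Cl)cc2)cc1`, 10000 nM
- compound 2, `Cc1ccsc1/C=C(\C(=O)c1ccc(Cl)cc1)S(=O)(=O)Cc1ccc(F)cc1`, 10000 nM
- compound 3, `Cc1ccc(CS(=O)(=O)/C(=C/c2sccc2C)C(=O)c2ccc(Cl)cc2)cc1`, 25000 nM

In a functional assay on DU-145 cells (Homo sapiens) for inhibition, read by trypan blue exclusion, with a stated time of 96 h (on this read-out lower numbers stand for stronger inhibition of growth and higher numbers for weaker inhibition of growth), compound 1 sits level with compound 2 at the digits printed, and together they give the lowest numbers of the three; compound 3 lies furthest away, with a 2.5-fold higher number from compound 1 to compound 3 (0.40 log units; beyond the scatter). The two remaining steps, no change at the digits printed from compound 1 to compound 2 (within the scatter) and a 2.5-fold higher number from compound 2 to compound 3 (0.40 log units; beyond the scatter), concern only the group on the sulfonyl sulfur.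

Compound 4, `Cc1ccc(S(=O)(=O)/C(=C/c2cc(C)cc(C)c2)C(=O)c2ccc(Cl)cc2)cc1`, differs from compound 1 at another site: 3,5-dimethylphenyl in place of 3-methylthiophen-2-yl on a double-bonded chain carbon bound to a double-bonded chain carbon

Among the compounds with values here, none of the measured steps touches this position, so they offer no direct guide. Each step seen so far was at most modest, and the three numbers cluster within a narrow band, so compound 4 is expected to stay near compound 1, with no step beyond the scatter: a 1.2-fold higher number from compound 1 to compound 4 (0.08 log units; within the scatter). In this assay compound 4 is therefore estimated at 12000 nM, with a range from 4000 nM to 40000 nM.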

Compound 4, concentration for 50% growth inhibition: 1000 nM
Beside the measured number, compound 4's estimate is 12-fold (1.08 log units) above it; measured number below the stated range.
By their numbers in this assay, from the lowest: compound 4; then compounds 1 and 2 (each within the scatter of the next); then compound 3.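

In this assay, the position on a double-bonded chain carbon bound to a double-bonded chain carbon proves responsive: 3,5-dimethylphenyl in place of 3-methylthiophen-2-yl gives a 10-fold lower number from compound 1 to compound 4 (1.00 log units; beyond the scatter). Within the data shown here, that is a larger step than any seen on the sulfonyl sulfur, where the biggest was a 2.5-fold higher number from compound 1 to compound 3 (0.40 log units; beyond the scatter), so the earlier compounds gave no sign of how much this site could move the number. No measurement available here bears on why this swap of a five-membered aromatic ring with 1 hetero atom for a six-membered aromatic ring of carbon only lowers the number.

Going by these compounds, the change alters the ring and its methyl groups together, so it remains open which of the two carries the step. Also open, on these data alone, are how a plain phenyl, a 3,5-dimethoxyphenyl or a pyridine ring would behave here, and whether 3,5-dimethylphenyl gives a similar step alongside the 4-fluorobenzyl or 4-methylbenzyl groups on the sulfonyl sulfur.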